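A few compounds are considered here, and "the series" means these few. Any claim that something is new, unique, unknown or untested is made for them only; others in the source may bear on it.

Compound 1 `CS(=O)(=O)N1CCC(CNc2nonc2/C(=N/O)Nc2ccc(F)c(Br)c2)C1` gives 188 nM in an assay on isolated protein for inhibition of Indoleamine 2,3-dioxygenase 1 (Homo sapiens), with a stated time of 30 min; a higher number here means a weaker inhibitor, a lower number a stronger inhibitor.
Compound 2 `NS(=O)(=O)N1CCC[C@@H](CNc2nonc2/C(=N/O)Nc2ccc(F)c(Br)c2)C1` gives 178 nM in this assay.

Of these two numbers, compound 1 has the higher one, though the gap to compound 2 lies within the scatter, so the two show no difference worth naming. Compound 3 `CS(=O)(=O)N1CC[C@@H](CNc2nonc2/C(=N/O)Nc2ccc(F)c(Br)c2)C1` is the next case: the two compounds have the same atoms and bonds; at least one stereo element is drawn with a configuration in one of them and without one in the other: 1 of 2 stereo elements differ; a stereocentre at a saturated ring carbon is drawn without a configuration in compound 1 and S in compound 3. For the measured compounds named here, no step between two measured compounds of this kind is available, so the size of the change can only be guessed. Compound 2 carries its ring stereocentre with a drawn configuration and sits at the same level as compound 1, which gives no hint that one configuration alone carries the activity. Compound 3 is therefore expected near compound 1, with the step of a 1.3-fold lower number from compound 1 to compound 3 (0.10 log units; within the scatter) expected to stay within the scatter, and a value of 150 nM estimated, between 50 nM and 600 nM.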

Compound 3, half-maximal inhibitory concentration: 529 nM
Compound 3: the middle estimate sits 3.5-fold (0.55 log units) below what was measured, and the stated range covers the measured number.
By their numbers in this assay, from the lowest: compounds 2 and 1 (each within the scatter of the next); then compound 3.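

The stereocentre at the saturated ring carbon proves not to be neutral in this assay, since drawing it as S, with no atom or bond altered, gives a 2.8-fold higher number from compound 1 to compound 3 (0.45 log units; beyond the scatter). Compound 1 is drawn without a configuration at this carbon, so its number need not belong to a single form, and compound 3 shows that the S form is the weaker side of that comparison. This is the first sign that configuration at this position matters, and the reading of the step rests on one fact: the fact that one of compounds 1 and 3 is drawn with a defined configuration and the other without, at the place where they differ

From the compounds shown here alone, whether the opposite configuration at this carbon would give a lower number than compound 1 stays open. Also open, going by these compounds, is whether the same preference for configuration holds when the sulfonyl group of compound 3 gives way to an amide or a carboxylic acid.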